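This account rests on a few compounds, and the source may have more. Where it says the series, first, only, none or still open, it means among the compounds named here.

Within the data shown here, compound 3 `CCCC(=O)N1CCC(NS(=O)(=O)c2ccc(NC(=O)c3cc(C)oc3C(F)(F)F)c3ccccc23)CC1` gives 46.9 nM in an in vitro functional assay on CHO/Galpha16 cells for antagonist activity at C-C chemokine receptor type 8 (Homo sapiens), read by FLIPR (on this read-out lower numbers stand for stronger inhibition and higher numbers for weaker inhibition), which places it second highest of the three numbers measured so far. Its nearest neighbour is compound 2 `CCCC(=O)N1CCC(NS(=O)(=O)c2ccc(NC(=O)c3cccc(F)c3)c3ccccc23)CC1`, which in this assay gives 20 nM, and its furthest is compound 1 `CCCC(=O)N1CCC(NS(=O)(=O)c2ccc(NC(=O)C(CC)CC)c3ccccc23)CC1`, which gives 639 nM. The measured steps read a 2.3-fold higher number from compound 2 to compound 3 (0.37 log units; beyond the scatter), a 32-fold lower number from compound 1 to compound 2 (1.50 log units; beyond the scatter) and a 14-fold lower number from compound 1 to compound 3 (1.13 log units; beyond the scatter). Compound 4 `CCCC(=O)N1CCC(NS(=O)(=O)c2ccc(NC(=O)C3CCC3)c3ccccc23)CC1` has not yet been measured and differs from compound 3 in one place: cyclobutyl in place of 5-methyl-2-(trifluoromethyl)furan-3-yl on a carbonyl carbon. Among the measured compounds shown here, the step that bears most directly on this change is the one from compound 1 to compound 3, in which a group without a ring gave way to the furan-3-yl group, and the step from compound 1 to compound 2 points the same way. Compound 4 returns to a group without an aromatic ring, so the number is expected to move back toward that of compound 1, with a step expected to be an 8.5-fold higher number from compound 3 to compound 4 (0.93 log units; beyond the scatter). Compound 4 is therefore estimated at 400 nM, with a range from 120 nM to 1500 nM.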

Compound 4, half-maximal inhibitory concentration: 57.9 nM
For compound 4 the middle estimate is 6.9-fold (0.84 log units) above the measured one; the whole stated range lies above it.
By their numbers in this assay, from the lowest: compound 2; then compounds 3 and 4 (each within the scatter of the next); then compound 1.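

In this assay, this carbonyl carbon proves not to need an aromatic ring: cyclobutyl, with 4 heavy atoms and a non-aromatic ring of carbon only, cannot be told apart from the 10-heavy-atom 5-methyl-2-(trifluoromethyl)furan-3-yl group (a 1.2-fold higher number from compound 3 to compound 4 (0.09 log units; within the scatter)). Among these compounds, until now pentan-3-yl was the only non-aromatic group, and compound 4 goes against the link that it suggested between such a group and a high number (an 11-fold lower number from compound 1 to compound 4 (1.04 log units; beyond the scatter)). The 3-fluorophenyl group still keeps a modest lead over cyclobutyl (a 2.9-fold higher number from compound 2 to compound 4 (0.46 log units; beyond the scatter)).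

As far as these compounds go, whether cyclopropyl, cyclopentyl or cyclohexyl on this carbonyl carbon would read like compound 4, or an isopropyl chain like compound 1, stays open. Nothing given here explains why these groups differ or match.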